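The compounds below may be only part of what the source reports. "The series", "measured", "known", "first", "only" and "open" are said of these compounds alone.

Compound 2, `OCCNc1[nH]ccc2ncnc1-2`, stands at the low end of the three numbers recorded in a functional assay (Homo sapiens) for inhibition of Nucleic Acid, tested at 100 uM; on this read-out higher numbers stand for more inhibition at the one concentration tested (going by the name of the read-out) and lower numbers for less inhibition: in this assay compound 2 gives 3%. Compound 3, `OC[C@H]1O[C@@H](n2cnc3c(S)nccc32)C[C@@H]1O`, is nearest, since compound 3 gives 10%, a gap that lies within the scatter, so the two cannot be ranked. Compound 1, `CCCCCCNc1[nH]ccc2ncnc1-2`, stands furthest away, as compound 1 gives 53%. Within the data shown here, the only measured step between neighbours is a number 50 percentage points lower from compound 1 to compound 2 (beyond the scatter), which shows that the group carried at this place can move the read-out a long way.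

Compound 4, `CSc1[nH]ccc2ncnc1-2`, has not yet been measured. It differs from compound 2 as follows: methylsulfanyl in place of (2-hydroxyethyl)amino on an aromatic carbon. Among the measured compounds shown here, no measured step pairs these two groups, so the change has no direct precedent, and the step from compound 1 to compound 2 only shows that this place is sensitive. Compound 4 is expected to stay in the low region, an expected a number 9 percentage points higher from compound 2 to compound 4 (within the scatter). Compound 4 is therefore estimated at 12%, with a range from 0% to 35%.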

Compound 4, a percentage reported as inhibition, at one concentration (the size of the read-out at that concentration, not a potency): 4%
Estimate against measurement, compound 4: 8 percentage points above; the range from low to high includes it.
By their numbers in this assay, from the lowest: compounds 2, 4 and 3 (each within the scatter of the next); then compound 1.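

In this assay the swap of (2-hydroxyethyl)amino for methylsulfanyl on the aromatic carbon gives a small step (a number 1 percentage points higher from compound 2 to compound 4 (within the scatter)), while the earlier change of chain on the nitrogen gave a large one (a number 50 percentage points lower from compound 1 to compound 2 (beyond the scatter)). The position therefore does not respond to every change: the entering group has no nitrogen or oxygen and 0 hydrogen-bond donors against 2 for the leaving group, yet the two cannot be told apart on this read-out. Nothing available explains this result.

The compounds shown leave open whether the long chain of compound 1 would give a similar number if joined through sulfur, as in hexylsulfanyl. They also leave open what a plain amino group would give at this carbon.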